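Compound 3 to compound 4: a step without a guide

The compounds below may be only part of what the source reports. "The series", "measured", "known", "first", "only" and "open" are said of these compounds alone.

Compound 1 `O=C(Nc1nccs1)c1cccc(Nc2ncc(F)c(Nc3ccc(F)cc3)n2)c1`: > 10000 nM, a limit
Compound 2 `COc1ccc(NC(=O)c2cccc(Nc3ncc(F)c(Nc4ccc(F)cc4)n3)c2)cc1`: > 10000 nM, a limit
Compound 3 `O=C(c1cccc(Nc2ncc(F)c(Nc3ccc(F)cc3)n2)c1)N1CCCCC1`: 13000 nM

Within the data shown here, in a functional assay on DU-145 cells (Homo sapiens) for antiproliferative activity, read by sulforhodamine B assay, with a stated time of 3 days (a higher number here means a weaker inhibitor of growth, a lower number a stronger inhibitor of growth), compound 3 gives 13000 nM, the only actual number in this small set. Compound 1 and compound 2 return only limits. The picture is set by the limit of > 10000 nM in this assay, at which 2 of the 3 values shown sit.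

The next compound, compound 4 `CN1CCC(C(=O)Nc2cccc(Nc3ncc(F)c(Nc4ccc(F)cc4)n3)c2)CC1`, carries ((1-methylpiperidin-4-yl)carbonyl)amino in place of (piperidin-1-yl)carbonyl on an aromatic carbon.

Two measured changes come closest, as both alter the group on the carbonyl carbon of compound 3: a step that the limit leaves unreadable from compound 1 to compound 3 and a step that the limit leaves unreadable from compound 2 to compound 3. Neither has a readable size, so neither offers a direction for this new change. No shift beyond the scatter is therefore expected, and a result reported only as a limit would be no surprise. The expected change is a 1.4-fold lower number from compound 3 to compound 4 (0.16 log units; within the scatter). For compound 4 the estimated value is 9000 nM, with an expected range from 2500 nM to 25000 nM.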

Compound 4, concentration for 50% growth inhibition: 1150 nM
The estimate for compound 4 lay 7.8-fold (0.89 log units) above the measured number; measured number outside the range, below it.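

In this assay, among these compounds, the step of an 11-fold lower number from compound 3 to compound 4 (1.05 log units; beyond the scatter) is the first in this set with a readable size, and it shows that replacing (piperidin-1-yl)carbonyl with ((1-methylpiperidin-4-yl)carbonyl)amino, at this place meta to a large group, can shift growth inhibition beyond the scatter. The same group also replaces the carbamoyl groups of the two other compounds, giving an at least 8.6-fold lower number from compound 2 to compound 4 (0.93 log units; beyond the scatter) and an at least 8.6-fold lower number from compound 1 to compound 4 (0.93 log units; beyond the scatter). Compound 1 and compound 2 each give a limit and not a number, so these two steps have only a minimum size: the limit of > 10000 nM in this assay, at which 2 of the 4 values shown sit.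

Going by these compounds, the change alters several things at once, so it stays open whether the step follows the amide hydrogen or the methyl-bearing ring nitrogen. On these data alone, whether a piperidin-4-yl group without the methyl, or a morpholine ring, would behave alike also remains open.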